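The source may report more compounds than this note shows. Statements on the series, on what has been measured and on what is new or still open speak of the compounds shown alone.

Compound 3 `COc1ccc(-c2nn(-c3ccccc3)cc2C(=O)Nc2nc3ccc(F)cc3s2)cc1` gives the lowest number of the three measured in a functional assay on PC-3 cells (Homo sapiens) for cytotoxicity, read by MTT assay, with a stated time of 72 h (a lower number here means a stronger inhibitor, a higher number a weaker inhibitor), at 4930 nM. Compound 2 `O=C(Nc1nc2ccc(F)cc2s1)c1cn(-c2ccccc2)nc1-c1ccc(F)cc1` gives 5260 nM, and the step of a 1.1-fold lower number from compound 2 to compound 3 (0.03 log units; within the scatter) is within the scatter. Compound 1 `Cc1ccc2nc(NC(=O)c3cn(-c4ccccc4)nc3-c3ccccc3)sc2c1` gives 15700 nM, a gap from compound 3 beyond the scatter.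

Compound 4 `COc1ccc(-c2nn(-c3ccccc3)cc2C(=O)Nc2nc3ccc(C)cc3s2)cc1` differs from compound 3 by methyl in place of fluoro on an aromatic carbon, that is 6-fluoro-1,3-benzothiazol-2-yl to 6-methyl-1,3-benzothiazol-2-yl. Within the data shown here, no measured step isolates this change: compound 1 carries the methyl but also differs from compound 2 elsewhere, so their values cannot be read as one step. The expected step of a 1.8-fold higher number from compound 3 to compound 4 (0.26 log units; within the scatter) is therefore a modest rise in this assay, leaning on the weaker number of compound 1. Compound 4 is expected at 9000 nM, with a range of 4000 nM to 22000 nM.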

Compound 4, half-maximal inhibitory concentration: 15900 nM
The estimate for compound 4 lay 1.8-fold (0.25 log units) below the measured number; measured number inside the range.
By their numbers in this assay, from the lowest: compounds 3 and 2 (each within the scatter of the next); then compounds 1 and 4 (each within the scatter of the next).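

The swap of 6-fluoro-1,3-benzothiazol-2-yl to 6-methyl-1,3-benzothiazol-2-yl now reads as a single step in this assay (a 3.2-fold higher number from compound 3 to compound 4 (0.51 log units; beyond the scatter)), so the group at this position matters, with fluoro giving the lower number. With the methyl held, the added methoxy leaves the number within the scatter (a 1.0-fold higher number from compound 1 to compound 4 (0.01 log units; within the scatter)). No supporting data explain the methyl step.

Open: how an amine, a nitrile or a carboxylic acid at this position would compare with fluoro and methyl.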